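A few compounds are considered here, and "the series" means these few. Any claim that something is new, unique, unknown or untested is made for them only; others in the source may bear on it.

For the measured compounds named here, in a functional assay on MCF7 cells (Homo sapiens) for antiproliferative activity, read by MTT assay, with a stated time of 24 h (a lower number here means a stronger inhibitor, a higher number a weaker inhibitor), compound 2 (`O=S(=O)(c1ccccc1)n1c(-c2cn(-c3ccccc3)nc2-c2ccc(F)cc2)nc2ccccc21`) gives 690 nM as the lower of the two numbers so far, and compound 1 (`FC(F)(F)c1ccc(-c2nn(-c3ccccc3)cc2-c2nc3ccccc3[nH]2)cc1`) gives 6330 nM as the higher. Compound 3 (`O=S(=O)(c1ccccc1)n1c(-c2cn(-c3ccccc3)nc2-c2ccc(C(F)(F)F)cc2)nc2ccccc21`) differs from compound 2 in one place, with trifluoromethyl in place of fluoro on an aromatic carbon, para to a large group (trifluoromethyl in place of fluoro on an aromatic carbon). Going by the values given here, no measured pair shows this change alone, so in this assay no step beyond the scatter is expected, in either direction. The expected step is small (a 1.1-fold higher number from compound 2 to compound 3 (0.04 log units; within the scatter)). For compound 3 the estimated value is 750 nM (expected range 260 nM to 2200 nM).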

Compound 3, half-maximal inhibitory concentration: 630 nM
Estimate against measurement, compound 3: 1.2-fold (0.08 log units) above; the range from low to high includes it.
By their numbers in this assay, from the lowest: compounds 3 and 2 (each within the scatter of the next); then compound 1.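

In this assay the change from 4-fluorophenyl to 4-(trifluoromethyl)phenyl gives a 1.1-fold lower number from compound 2 to compound 3 (0.04 log units; within the scatter) and so shows that this place, para to a large group, takes trifluoromethyl as well as fluoro. For the compounds shown here, with trifluoromethyl held, phenylsulfonyl in place of hydrogen on the aromatic nitrogen gives a 10-fold lower number from compound 1 to compound 3 (1.00 log units; beyond the scatter) as the first reading of that change alone. No measured evidence bears on either step.

Going by these compounds, whether an amine, a methoxy group or a carboxylic acid at this place would keep the number stays open. So does whether methyl or acetyl on that nitrogen, in place of phenylsulfonyl, would give a similar step.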